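Amide side chain and tolerated concentration on the shared core

The compounds below may be only part of what the source reports. "The series", "measured", "known", "first", "only" and "open" are said of these compounds alone.

Compound 1 `O=C(Nc1ccccc1)c1c(NO)cc(-c2ccccc2)oc1=O` carries a phenyl on the amide-type nitrogen; in an ADME assay on Huh-7 cells (Homo sapiens) for cytotoxicity, read by a luciferase reporter and WST assay, with a stated time of 3 days (a higher number here means that more compound is tolerated, a lower number that less compound is tolerated), compound 1 gives 11600 nM. Compound 2 `Cc1ccc(NC(=O)c2c(NO)cc(-c3ccccc3)oc2=O)cc1` reaches only a limit of the assay, > 20000 nM. Compound 3 `CCCNC(=O)c1c(NO)cc(-c2ccccc2)oc1=O`, with propyl in place of phenyl on that nitrogen, likewise reaches only a limit, > 20000 nM. The two measured steps that start from a number are an at least 1.7-fold higher number from compound 1 to compound 2 (0.23 log units; that floor lies within the scatter) and an at least 1.7-fold higher number from compound 1 to compound 3 (0.23 log units; that floor lies within the scatter). A third step is a step that the two limits leave unreadable from compound 2 to compound 3, since both ends sit at the limit of > 20000 nM in this assay, at which 2 of the 3 values shown sit. Compound 3 therefore stands at the upper boundary of what this series has shown, together with compound 2, and no order between the two can be read.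

Compound 4 `O=C(NCCCO)c1c(NO)cc(-c2ccccc2)oc1=O` differs from compound 3 by hydroxy in place of hydrogen on a saturated chain carbon, three bonds along the chain from an amide-type nitrogen. Going by the values given here, no measured step covers such a change; the steps that exist bear on the amide substituent only as phenyl, 4-methylphenyl or propyl, and both steps away from compound 1 were upward with a floor inside the scatter. For compound 4 a change no larger than the scatter is expected, a step that the limit leaves unreadable from compound 3 to compound 4. The value for compound 4 is accordingly estimated at 25000 nM, within 10000 nM to 60000 nM, and most probably it will again be reported only as a limit.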

Compound 4, half-maximal cytotoxic concentration: > 20000 nM
Compound 4: no number, only a limit; the forecaster's own chance of this, stated with the estimate: 70%; the middle value is on the limit's open side.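

Hydroxy in place of hydrogen, on a saturated chain carbon three bonds along the chain from an amide-type nitrogen, is the first change shown on the propyl chain itself, and in this assay it does not bring the read-out down to a number. The steps from compound 3 to compound 4 and from compound 2 to compound 4 cannot be read, so the result shows only that 3-hydroxypropyl stays at the limit, not that hydroxy leaves the tolerated concentration unchanged. The one readable step is an at least 1.7-fold higher number from compound 1 to compound 4 (0.23 log units; that floor lies within the scatter), and with it compound 1 remains the only compound in this set with an actual number, while 4-methylphenyl, propyl and 3-hydroxypropyl on that nitrogen all end at the same boundary: the limit of > 20000 nM in this assay, at which 3 of the 4 values shown sit.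

Going by these compounds, how far past that limit compound 2, compound 3 and compound 4 lie remains open, and with it any order among them. Also open, on these data alone, is whether an amine or a carboxylic acid at the end of the chain, or a longer chain, would stay at the limit or return a number.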